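The source may report more compounds than this note shows. Statements on the series, on what has been measured and on what is new or still open speak of the compounds shown alone.

Measured compounds:
- compound 1, `CCCOC(=O)Nc1ccc([Se]C#N)cc1`: 51900 nM
- compound 2, `CCCCCCOC(=O)Nc1ccc([Se][Se]c2ccc(NC(=O)OCCCCCC)cc2)cc1`: 42600 nM
- compound 3, `CCCCOC(=O)Nc1ccc([Se][Se]c2ccc(NC(=O)OCCCC)cc2)cc1`: 55000 nM

In a functional assay on HT-29 cells (Homo sapiens) for cytotoxicity, read by MTT assay, with a stated time of 72 h (a lower number here means a stronger inhibitor of growth, a higher number a weaker inhibitor of growth), compound 1 gives 51900 nM, the second highest of the three numbers. Compound 3 gives 55000 nM and compound 2 gives 42600 nM; both lie within the scatter of compound 1, so no order can be read among the three.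

Compound 4, `CCOC(=O)Nc1ccc([Se]C#N)cc1`, is not yet measured. It differs from compound 1 by hydrogen in place of methyl on a saturated chain carbon, two bonds along the chain from an oxygen next to a carbonyl group. Among the compounds with values here, no pair of measured compounds shows this change, so there is no step to lean on; the change is small and the expectation is a step no larger than the scatter, in no settled direction. Compound 4 is therefore expected to give about 52000 nM, with a range from 26000 nM to 104000 nM. The estimated step of a 1.0-fold higher number from compound 1 to compound 4 (0.00 log units; within the scatter) is meant as essentially flat.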

Compound 4, concentration for total growth inhibition: 38000 nM
Beside the measured number, compound 4's estimate is 1.4-fold (0.14 log units) above it; the measured number falls inside the stated range.
By their numbers in this assay, from the lowest: compounds 4, 2, 1 and 3 (each within the scatter of the next).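

In this assay, this position now has its first direct reading: there is a 1.4-fold lower number from compound 1 to compound 4 (0.14 log units; within the scatter), a step that stays within the scatter. Going from propoxy to ethoxy, the methyl can therefore be replaced by hydrogen at this place without any difference that can be read in this assay. No measurement at hand bears on why this is so.

The compounds shown leave open whether a longer chain, or an amine in place of this methyl, would stay within the scatter of compound 1. One step cannot establish a trend along the chain.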